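Working notes: from compound 3 to compound 4

The compounds below may be only part of what the source reports. "The series", "measured", "known", "first", "only" and "open" are said of these compounds alone.

Measured in a functional assay on DU-145 cells (Homo sapiens) for cytotoxicity, read by MTT assay, with a stated time of 72 h; on this read-out higher numbers stand for weaker inhibition and lower numbers for stronger inhibition:
compound 1, `COc1cccc(/C=C/C(=O)Nc2cc(OC)c(OC)c(OC)c2)c1`: 3200 nM
compound 2, `COc1ccc(/C=C/C(=O)Nc2cc(C(=O)c3cc(OC)c(OC)c(OC)c3)ccc2OC)cc1`: 12800 nM
compound 3, `COc1cccc(/C=C/C(=O)Nc2cc(C(=O)c3cc(OC)c(OC)c(OC)c3)ccc2OC)c1`: 6200 nM

Compound 3 stands second highest of the three numbers. Its gap to compound 1 lies within the scatter, so no order between those two is claimed. The step of a 2.1-fold lower number from compound 2 to compound 3 (0.31 log units; beyond the scatter) is beyond the scatter, though modest.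

Compound 4, `COc1cc(/C=C/C(=O)Nc2cc(C(=O)c3cc(OC)c(OC)c(OC)c3)ccc2OC)ccc1F`, differs from compound 3 by fluoro in place of hydrogen on an aromatic carbon. Going by the values given here, no measured step adds a fluoro anywhere, so there is no direct precedent for this change. Among the compounds with values here, the only measured step on the same ring, a 2.1-fold lower number from compound 2 to compound 3 (0.31 log units; beyond the scatter), moved a methoxy group rather than adding an atom, and was modest; it sets a rough scale for what a small change on this ring has done so far. A step no larger than that, in either direction, would not be surprising. For compound 4 in this assay the expected outcome is 5500 nM, with a range from 2500 nM to 12000 nM. The expected step of a 1.1-fold lower number from compound 3 to compound 4 (0.05 log units; within the scatter) is thus none beyond the scatter.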

Compound 4, half-maximal inhibitory concentration: 12100 nM
The estimate for compound 4 lay 2.2-fold (0.34 log units) below the measured number; the whole stated range lies below it.
By their numbers in this assay, from the lowest: compounds 1, 3, 4 and 2 (each within the scatter of the next, the first and the last beyond it).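

In this assay, going by these compounds alone, fluoro on the aromatic carbon ortho to a methoxy group and para to a large group gives the first reading at this position, a 2.0-fold higher number from compound 3 to compound 4 (0.29 log units; within the scatter), so neither a gain nor a loss can be claimed for this change. The step of a 1.1-fold lower number from compound 2 to compound 4 (0.02 log units; within the scatter) also leaves compound 4 unordered against compound 2, whereas the step of a 2.1-fold lower number from compound 2 to compound 3 (0.31 log units; beyond the scatter), which only moved the methoxy group, is printed as beyond the scatter. No measurement here bears on what lies behind this result.

As far as these compounds go, whether another group on this carbon, such as chloro, hydroxy or an amine, would give a step beyond the scatter stays open. So does whether fluoro would read the same on the 4-methoxyphenyl ring of compound 2.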